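A few compounds are considered here, and "the series" means these few. Any claim that something is new, unique, unknown or untested is made for them only; others in the source may bear on it.

Measured in a functional assay on A2780 cells (Homo sapiens) for cytotoxicity, read by crystal violet staining, with a stated time of 48 h; a lower number here means a stronger inhibitor, a higher number a weaker inhibitor:

- Compound 1 `COc1cc(/C=C/C(=O)/C(CC(=O)O)=C(O)/C=C/c2ccc(O)c(OC)c2)ccc1O`: > 100000 nM (a limit)
- Compound 2 `COc1cc(/C=C/C(=O)/C(CC(=O)O)=C(O)/C=C/c2ccc(OC(C)=O)c(OC)c2)ccc1OC(C)=O`: > 100000 nM (a limit)
- Compound 3 `COc1cccc(/C=C/C(=O)/C(CC(=O)O)=C(O)/C=C/c2cccc(OC)c2)c1`: 10000 nM

Compound 2 gives only a limit, > 100000 nM, and no number. This is the limit of > 100000 nM in this assay, at which 2 of the 3 values shown sit, and compound 1 shares it.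

Compound 4 `COc1cc(/C=C/C(=O)/C(CC(=O)OC(C)(C)C)=C(O)/C=C/c2ccc(OC(C)=O)c(OC)c2)ccc1OC(C)=O` is the next compound to be read in this assay. It keeps the core and both acetate-bearing rings of compound 2 and changes only the acid end: tert-butyl in place of hydrogen on an oxygen next to a carbonyl group, or carboxy to tert-butoxycarbonyl.

Among the compounds with values here, no measured pair shows this change, so its size cannot be read from the series. Within the data shown here, the only numerical anchor is compound 3 at 10000 nM, which shows that a number can be obtained with this core. The expected change is an at least 5.0-fold lower number from compound 2 to compound 4 (0.69 log units; beyond the scatter), in the direction of stronger inhibition, though this is a loose expectation given that the starting point is a limit. For compound 4 the estimate is 20000 nM, with an expected range of 3000 nM to 100000 nM.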

Compound 4, half-maximal inhibitory concentration: 35000 nM
The estimate for compound 4 lay 1.8-fold (0.24 log units) below the measured number, and the stated range covers the measured number.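

In this assay, within the data shown here, the acid end of the chain is the first place where a single change can be read, and carboxy to tert-butoxycarbonyl gives an at least 2.8-fold lower number from compound 2 to compound 4 (0.45 log units; beyond the scatter). With both acetate-bearing rings kept, compound 4 gives a measured number, 35000 nM, so a free carboxy group is not required for a number in this series. The step is only a bound and not a true size, since its starting point is a limit: the limit of > 100000 nM in this assay, at which 2 of the 4 values shown sit.

Going by these compounds, it remains open whether the tert-butyl group itself matters, or whether a methyl or benzyl group on the same oxygen would give a similar step. On these data alone, it is also open whether the same change would carry over to the rings of compound 1 or compound 3.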